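This account rests on a few compounds, and the source may have more. Where it says the series, first, only, none or still open, it means among the compounds named here.

Compound 1 `Fc1ccc2[nH]c(-c3cn(-c4ccccc4)nc3-c3ccccc3)nc2c1` gives > 50000 nM in an ADME assay on HaCaT cells (Homo sapiens) for cytotoxicity, read by MTT assay, with a stated time of 48 h; a lower number here means a stronger inhibitor, a higher number a weaker inhibitor; this value is a limit of the assay.
Compound 2 `Clc1ccc2[nH]c(-c3cn(-c4ccccc4)nc3-c3ccccc3)nc2c1` gives > 50000 nM in this assay, again a limit.
Compound 3 `Fc1ccc(-c2nn(-c3ccccc3)cc2-c2nc3ccccc3[nH]2)cc1` gives > 50000 nM in this assay, also a limit.

All three values sit at the limit of > 50000 nM in this assay, at which 3 of the 3 values shown sit. From compound 1 to compound 2 the change is chloro in place of fluoro on an aromatic carbon, and in this assay it gives a step that the two limits leave unreadable from compound 1 to compound 2. Compound 4 `Clc1ccc(-c2nn(-c3ccccc3)cc2-c2nc3ccccc3[nH]2)cc1` has not been measured; it differs from compound 3 by chloro in place of fluoro on an aromatic carbon, the same kind of change, though here the place is on a six-membered aromatic ring of carbon only, para to a large group, not part of a fused or bridged system of two rings. The difference between the cores of compound 1 and compound 3 is not broken down here. Compound 1 and compound 2 both stand at the limit of > 50000 nM in this assay, at which 3 of the 3 values shown sit, and on that rests the expectation. The expected step in this assay is a step that the limit leaves unreadable from compound 3 to compound 4. Compound 4 is estimated at 60000 nM, between 30000 nM and 150000 nM.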

Compound 4, half-maximal inhibitory concentration: > 50000 nM
Compound 4: no number, only a limit (the forecaster's own chance of this, stated with the estimate: 85%); the middle value is on the limit's open side.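

Compound 3 and compound 4 are both limits and not numbers, so no step can be read between them: the limit of > 50000 nM in this assay, at which 4 of the 4 values shown sit.
The compounds shown leave open what real value any of them would give in this assay, and whether chloro in place of fluoro changes it.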